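Trimming the chain on the amine nitrogen in a ring

The source may hold more compounds than are shown below. What is called first, only, known or untested is meant among the compounds shown, and "the series" means these compounds.

Compound 2 `CCCN1CCC(C(=O)Nc2cc(Cl)c(N)cc2OC)CC1` stands only as a limit: in a functional assay on the whole organism for antagonist activity, with Mus musculus as the target (on this read-out higher numbers stand for an effect only at larger amounts of compound and lower numbers for an effect already at smaller amounts), compound 2 gives > 10 mg/kg, which is a limit of the assay and not a number. The two other measured compounds also give limits. Compound 1 `COc1cc(N)c(Cl)cc1NC(=O)C1CCN(Cc2ccccc2Cl)CC1` gives > 4 mg/kg in this assay, a limit. Compound 3 `COc1cc(N)c(Cl)cc1NC(=O)C1CCN(CC2CCCC2)CC1` gives > 10 mg/kg in this assay, again a limit. Thus the limit of > 10 mg/kg in this assay, at which 2 of the 3 values shown sit, and the limit of > 4 mg/kg in this assay, at which 1 of the 3 values shown sits, are the whole of the evidence, and the steps a step that the two limits leave unreadable from compound 1 to compound 2, a step that the two limits leave unreadable from compound 1 to compound 3 and a step that the two limits leave unreadable from compound 2 to compound 3 cannot be sized. Compound 4 `CCN1CCC(C(=O)Nc2cc(Cl)c(N)cc2OC)CC1` differs from compound 2 by hydrogen in place of methyl on a saturated chain carbon, two bonds along the chain from an amine nitrogen in a ring. Among the measured compounds shown here, no measured step bears on this change, since the compounds carrying ethyl, cyclopentyl or 2-chlorophenyl on a saturated chain carbon bound to an amine nitrogen in a ring all sit at limits; neither direction nor size can be drawn from them. Compound 4 is expected to stay near the limit of compound 2, as a step that the limit leaves unreadable from compound 2 to compound 4. Compound 4 is estimated at 12 mg/kg, with a range of 6 mg/kg to 30 mg/kg, and most likely it too will be reported only as a limit.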

Compound 4, dose for half-maximal effect: > 10 mg/kg
Compound 4 gave a limit, no number; the forecaster's own chance of this, stated with the estimate: 75%; the middle value is on the limit's open side.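

In this assay compound 4 gives > 10 mg/kg, a limit of the assay and not a number. Among the compounds shown here, no step from compound 1, compound 2 or compound 3 to compound 4 can be read. The compounds shown leave open whether any change on the amine nitrogen in a ring shifts the half-maximal dose, and in which direction.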